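The compounds below may be only part of what the source reports. "The series", "measured", "known", "first", "only" and "open" are said of these compounds alone.

Working notes on the amide series. The shared core of compound 1 `COc1cc2ncnc(Nc3ccc(NC(=O)c4cccc(C)c4)cc3)c2cc1OC` carries a 3-methylphenyl on the carbonyl carbon, and in a functional assay on MCF7 cells (Homo sapiens) for inhibition, read by MTT assay (a lower number here means a stronger inhibitor, a higher number a weaker inhibitor), compound 1 gives 13000 nM, the lowest of the two numbers in hand. Within the data shown here, compound 2 `CCc1ccc(C(=O)Nc2ccc(Nc3ncnc4cc(OC)c(OC)cc34)cc2)cc1` is the only measured neighbour: in this assay compound 2 gives 65000 nM, and the step from compound 1 to compound 2 is a 5.0-fold higher number from compound 1 to compound 2 (0.70 log units; beyond the scatter), a change of the aryl group on the carbonyl carbon that cost potency.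

Compound 3 `COc1cc2ncnc(Nc3ccc(NC(=O)c4ccc(Cl)c(Cl)c4)cc3)c2cc1OC` is not yet measured. Its difference from compound 1 is 3,4-dichlorophenyl in place of 3-methylphenyl on a carbonyl carbon. Among the measured compounds shown here, the one step that bears on it, a 5.0-fold higher number from compound 1 to compound 2 (0.70 log units; beyond the scatter), shows that altering this aryl group weakened inhibition, though that change was to an alkyl pattern rather than to two chlorines. A modest loss is therefore expected, roughly a 1.5-fold higher number from compound 1 to compound 3 (0.19 log units; within the scatter). Compound 3 is estimated at 20000 nM in this assay, with a range of 7000 nM to 60000 nM.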

Compound 3, half-maximal inhibitory concentration: 25000 nM
For compound 3 the middle estimate is 1.3-fold (0.10 log units) below the measured one, within the range that was stated.
By their numbers in this assay, from the lowest: compounds 1 and 3 (each within the scatter of the next); then compound 2.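

In this assay, among these compounds, the position on the carbonyl carbon accepts 3,4-dichlorophenyl in place of 3-methylphenyl with no change beyond the scatter (a 1.9-fold higher number from compound 1 to compound 3 (0.28 log units; within the scatter)), so a change of aryl group here need not shift the number, which the single earlier step could not show. The same group in place of 4-ethylphenyl does give a step beyond the scatter (a 2.6-fold lower number from compound 2 to compound 3 (0.41 log units; beyond the scatter)), which leaves compound 2 apart from compounds 1 and 3 among the three aryl groups. No measured property is available to account for these differences.

Still open, from the compounds shown here alone, is whether the carbonyl carbon accepts anything other than a substituted phenyl, such as a pyridine ring or a simple alkyl chain. Also open, going by these compounds, is whether a phenyl bearing a single chlorine, an amine or a carboxylic acid would move the number beyond the scatter of compound 1.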